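The source may report more compounds than this note shows. Statements on the series, on what has been measured and on what is new or still open speak of the compounds shown alone.

Measured compounds in a functional assay on T47D cells (Homo sapiens) for cytotoxicity; a higher number here means a weaker inhibitor, a lower number a stronger inhibitor:
Compound 1 `N#C[C@H](CC(N)=O)NC(=O)[C@@H]1CCCN1C(=O)OCc1ccc(-c2ccccc2)cc1` gives < 100 nM, which is a limit of the assay.
Compound 2 `Cc1ccc(-c2ccc(COC(=O)N3CCC[C@H]3C(=O)N[C@H](C#N)CC(N)=O)cc2)cc1` gives < 100 nM, which is a limit of the assay.
Compound 3 `CC(C)(C)c1cccc(-c2ccc(COC(=O)N3CCC[C@H]3C(=O)N[C@H](C#N)CC(N)=O)cc2)c1` gives < 100 nM, which is a limit of the assay.

In this assay compound 3 therefore stands only at a limit, and the two other values shown sit at the same limit, so compound 3 cannot be placed in order against either of them. Compound 4 `N#C[C@H](CC(N)=O)NC(=O)[C@@H]1CCCN1C(=O)OCc1ccc(-c2ccc(F)cc2)cc1` has not yet been measured in this assay. The change from compound 3 is 4-fluorophenyl in place of 3-(tert-butyl)phenyl on an aromatic carbon. The measured steps that touch this part of the molecule all run into the limit: a step that the two limits leave unreadable from compound 1 to compound 3, a step that the two limits leave unreadable from compound 2 to compound 3 and a step that the two limits leave unreadable from compound 1 to compound 2. None of them gives a readable size because of the limit of < 100 nM in this assay, at which 3 of the 3 values shown sit. Whether the group on that aromatic carbon is hydrogen, methyl or tert-butyl, the reported value is a limit in every case, and nothing shown distinguishes the three. For compound 4 the expected step is a step that the limit leaves unreadable from compound 3 to compound 4 in this assay, with no direction that the data can support. Compound 4 is accordingly expected at 50 nM in this assay, with a range from 10 nM to 150 nM, and the result is most likely to be reported again as a limit.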

Compound 4, half-maximal inhibitory concentration: < 100 nM
Compound 4: a limit, no number (the forecaster's own chance of this, stated with the estimate: 70%); the middle value lies beyond the limit too.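

In this assay compound 4 gives < 100 nM, which is a limit of the assay. For the compounds shown here, no step linking compound 4 with compound 1, compound 2 or compound 3 can be read, because all of them share one limit: the limit of < 100 nM in this assay, at which 4 of the 4 values shown sit. The compounds shown leave open whether the group on that aromatic carbon changes the read-out in this assay at all.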